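Ortho substituent survey on the shared propanamide core

A few compounds are considered here, and "the series" means these few. Any claim that something is new, unique, unknown or untested is made for them only; others in the source may bear on it.

Measured so far:
compound 1 `CC(C(=O)NCc1ccc(C(F)(F)F)cc1N1CCCCCCC1)c1ccc(NS(C)(=O)=O)c(F)c1` with 2.8 nM
compound 2 `CC(C(=O)NCc1ccc(C(F)(F)F)cc1OCc1ccccc1)c1ccc(NS(C)(=O)=O)c(F)c1` with 0.9 nM

In an assay on CHO cells for antagonist activity at transient receptor potential cation channel subfamily V member 1 (Homo sapiens), read by FLIPR (on this read-out lower numbers stand for stronger inhibition and higher numbers for weaker inhibition), compound 2 holds the lowest number of the two. For the measured compounds named here, the step of a 3.1-fold lower number from compound 1 to compound 2 (0.49 log units; beyond the scatter) is the only change read on this core so far; it lies beyond the scatter and favours the benzyloxy compound 2.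

Compound 3 `CCCCCCSc1cc(C(F)(F)F)ccc1CNC(=O)C(C)c1ccc(NS(C)(=O)=O)c(F)c1` is not yet measured. Against compound 2 it carries hexylsulfanyl in place of benzyloxy on an aromatic carbon. Going by the values given here, no measured step bears directly on this exchange; the single step of a 3.1-fold lower number from compound 1 to compound 2 (0.49 log units; beyond the scatter) shows only that the group at this position can move this assay by a modest amount, and that a six-membered aromatic ring there is tolerated well.

Expectation: the chain of compound 3 is a third kind of group at this position, and no anchor exists for it. The estimate for compound 3 is therefore a small step, a 2.2-fold higher number from compound 2 to compound 3 (0.35 log units; beyond the scatter), towards a somewhat higher number, with a wide range. Compound 3 is expected at 2 nM in this assay, between 0.6 nM and 8 nM.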

Compound 3, inhibition constant: 1.8 nM
For compound 3 the middle estimate is 1.1-fold (0.05 log units) above the measured one; the measured number falls inside the stated range.
By their numbers in this assay, from the lowest: compounds 2, 3 and 1 (each within the scatter of the next, the first and the last beyond it).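

On the shared core, an open chain with no ring holds this position in this assay: hexylsulfanyl cannot be told apart from benzyloxy (a 2.0-fold higher number from compound 2 to compound 3 (0.30 log units; within the scatter)) or from the eight-membered ring group (a 1.6-fold lower number from compound 1 to compound 3 (0.19 log units; within the scatter)). Across these three compounds, a number in this range therefore needs no ring of either kind in this group, and a sulfur-linked group reads alongside the oxygen-linked and nitrogen-linked ones. For the compounds shown here, the one step beyond the scatter remains (a 3.1-fold lower number from compound 1 to compound 2 (0.49 log units; beyond the scatter)), compound 3 sits within the scatter of both its ends, and no supporting data on hand explain any of these numbers.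

The compounds shown leave open whether the sulfur link or the length of the chain matters here, since hexylsulfanyl changes both relative to benzyloxy; a hexyloxy group and a shorter chain such as butylsulfanyl would separate the two. They also leave open how far this tolerance extends beyond uncharged groups, which a carboxylic acid or a primary amine at the end of the chain would test.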